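From fluoro to bromo on the shared core

The source may hold more compounds than are shown below. What is called first, only, known or untested is meant among the compounds shown, and "the series" means these compounds.

- Compound 1 `O=C(/C=C/c1csc2ccccc12)c1ccccc1O`: 5300 nM
- Compound 2 `O=C(/C=C/c1csc2ccccc12)c1cc(F)ccc1O`: 8400 nM
- Compound 3 `O=C(/C=C/c1csc2ccccc12)c1cc(Br)ccc1O`: not yet measured

Among the compounds with values here, only two compounds have numbers in a functional assay on MDA-MB-231 cells (Homo sapiens) for antiproliferative activity, read by sulforhodamine B assay, with a stated time of 72 h (on this read-out lower numbers stand for stronger inhibition and higher numbers for weaker inhibition), so compound 2 has a single measured neighbour, and the two values lie within the scatter of each other. Compound 3 differs from compound 2 in one place: bromo in place of fluoro on an aromatic carbon. This is bromo in place of fluoro on an aromatic carbon, para to a hydroxy group.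

Within the data shown here, one measured step bears on this change. It concerns the same aromatic carbon: fluoro in place of hydrogen gives a 1.6-fold higher number from compound 1 to compound 2 (0.20 log units; within the scatter). Among the measured compounds shown here, no bromo compound has yet been measured, so the data offer only this indirect guide. With so small a step at this place, a step beyond the scatter is not expected in this assay, in either direction. The expected step is a 1.2-fold lower number from compound 2 to compound 3 (0.08 log units; within the scatter). For compound 3 the estimated value is 7000 nM, with an expected range of 2800 nM to 17000 nM.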

Compound 3, half-maximal inhibitory concentration: 840 nM
Compound 3: the middle estimate sits 8.3-fold (0.92 log units) above what was measured; the measured number lies below the stated range.
By their numbers in this assay, from the lowest: compound 3; then compounds 1 and 2 (each within the scatter of the next).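

In this assay, this position proves sensitive to the group it carries, which the earlier pair did not reveal: a 1.6-fold higher number from compound 1 to compound 2 (0.20 log units; within the scatter), but bromo in place of fluoro gives a 10-fold lower number from compound 2 to compound 3 (1.00 log units; beyond the scatter), and bromo in place of hydrogen gives a 6.3-fold lower number from compound 1 to compound 3 (0.80 log units; beyond the scatter). Among the three compounds shown, compound 3 alone stands apart from the others at this carbon para to a hydroxy group, so the fluoro compound was a poor guide to what a bromo group would do here. Nothing on hand explains why bromo and fluoro differ so much at this place.

With only hydrogen, fluoro and bromo compared, the compounds shown do not tell whether the lower number is particular to bromo or would also appear with chloro, iodo, methoxy or an amine on the same carbon. They also leave open whether bromo would give a similar step on another carbon of this ring, or in a compound where a methoxy group replaces the hydroxy group.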